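The source may report more compounds than this note shows. Statements on the series, on what has been measured and on what is new or still open speak of the compounds shown alone.

Compound 1 `Cc1cc(=O)oc2ccc(OCC(O)CN3CCN(c4ccccc4)CC3)cc12`: in a functional assay on ileum for antagonist activity at histamine H1 receptor (Cavia porcellus), tested at 1 mg/mL (a lower number here means that less compound is needed, a higher number that more compound is needed for the effect), compound 1 gives 0.0085 ug/mL.
Compound 2 `CCCNCC(O)COc1ccc2c(-c3ccccc3)cc(=O)oc2c1`: in this assay compound 2 gives 0.0085 ug/mL.

The two measured compounds share the same oxygen-linked hydroxy-bearing chain on a coumarin-type core, and they stand level in this assay: the value of compound 2 matches that of compound 1 at the digits shown, which means no difference beyond the usual scatter. Since the two are not directly related by a single change, nothing can be said about the effect of any one change between them.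

Compound 3 `O=c1cc(-c2ccccc2)c2ccc(OCC(O)CN3CCNCC3)cc2o1` has not yet been measured. It differs from compound 2 in one place: piperazin-1-yl in place of propylamino on a saturated chain carbon, two bonds along the chain from an oxygen on a saturated carbon. So the open-chain amine is exchanged for a ring amine with a free second nitrogen, on the same chain carbon.

Within the data shown here, with no measured step of this kind available, the expectation rests only on the fact that compound 1, which carries a different piperazine, and compound 2 give the same value. On that basis compound 3 is expected to change by a 1.8-fold higher number from compound 2 to compound 3 (0.25 log units; within the scatter), a step not clearly beyond the scatter, and the estimated value for compound 3 is 0.015 ug/mL with a range of 0.004 ug/mL to 0.06 ug/mL.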

Compound 3, half-maximal effective concentration: 0.0086 ug/mL
The estimate for compound 3 lay 1.7-fold (0.24 log units) above the measured number; the measured number falls inside the stated range.
By their numbers in this assay, from the lowest: compounds 1, 2 and 3 (each within the scatter of the next).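

In this assay, among these compounds, the exchange of propylamino for piperazin-1-yl gives a 1.0-fold higher number from compound 2 to compound 3 (0.01 log units; within the scatter), the first step that can be read at this position. On this saturated chain carbon, two bonds along the chain from an oxygen on a saturated carbon, the open propylamino group and the larger piperazin-1-yl group, with its six-membered non-aromatic ring and second nitrogen, therefore read as level in this test. Nothing given here accounts for this level reading.

This single step comes from one assay and one core, so it sets no general rule for amines at this position. As far as these compounds go, whether a morpholin-4-yl ring, which has an oxygen in place of the second nitrogen, or a longer butylamino chain would also stand level with compound 2 stays open, as does the effect of a phenyl group on the second piperazine nitrogen on the core of compound 3.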